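Methyl to hydrogen on the phenolic oxygen of compound 2

A few compounds are considered here, and "the series" means these few. Any claim that something is new, unique, unknown or untested is made for them only; others in the source may bear on it.

Two compounds share a core and differ elsewhere. Compound 1 `Cc1cc(O)cc(-c2nn(CC#N)cc2-c2ccnc(-c3ccc(Oc4ccccc4)cc3)c2)c1` gives 7180 nM in a functional assay on DU-145 cells (Homo sapiens) for inhibition, read by sulforhodamine B assay, with a stated time of 48 h (on this read-out lower numbers stand for stronger inhibition of growth and higher numbers for weaker inhibition of growth), while compound 2 `COc1cc(C)cc(-c2nn(CC#N)cc2-c2ccnc(-c3ccc(N(C)C)cc3)c2)c1` gives 1110 nM and thus stands at the lower of the two numbers, its gap to compound 1 lying beyond the scatter. Compound 3 `Cc1cc(O)cc(-c2nn(CC#N)cc2-c2ccnc(-c3ccc(N(C)C)cc3)c2)c1` differs from compound 2 by hydrogen in place of methyl on an oxygen on an aromatic ring. Within the data shown here, no measured pair isolates this change; compound 1 carries the hydroxy but also a different group on the other ring. A small step from a 1.4-fold higher number from compound 2 to compound 3 (0.13 log units; within the scatter) toward a higher number is expected. Compound 3 is expected to give 1500 nM, between 600 nM and 4500 nM.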

Compound 3, concentration for total growth inhibition: 8570 nM
Compound 3: middle estimate off by 5.7-fold (0.76 log units), on the low side; measured number above the stated range.
By their numbers in this assay, from the lowest: compound 2; then compounds 1 and 3 (each within the scatter of the next).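

In this assay, the methyl on this oxygen proves to matter: hydrogen in its place weakens growth inhibition (a 7.7-fold higher number from compound 2 to compound 3 (0.89 log units; beyond the scatter)). With the hydroxy in place, phenoxy and dimethylamino on the other ring cannot be told apart (a 1.2-fold higher number from compound 1 to compound 3 (0.08 log units; within the scatter)), so the advantage of compound 2 belongs to its methoxy, at least in this pair. Nothing available explains why the methyl matters. From the compounds shown here alone, whether an ethyl or a longer chain on this oxygen would hold the number of compound 2 stays open, as does whether phenoxy and dimethylamino would still match alongside a methoxy.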